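Compound 4: 1-Methylpyrazol-3-yl Replaces (Ethylsulfonyl)amino

This account rests on a few compounds, and the source may have more. Where it says the series, first, only, none or still open, it means among the compounds named here.

Compound 2 `CCS(=O)(=O)Nc1cccc2c1CCC2c1ncc[nH]1` holds the lowest of the two single numbers in a functional assay on CHO cells for agonist activity at Alpha-1A adrenergic receptor (Homo sapiens), read by FLIPR and calcium flux (a lower number here means that less compound is needed, a higher number that more compound is needed for the effect), giving 32 nM; its nearest neighbour, compound 1 `Cc1ccc2c(c1NS(C)(=O)=O)CCC2c1ncc[nH]1`, gives 33 nM, a gap within the usual scatter, so neither can be called the more potent. Compound 3 `CS(=O)(=O)Nc1cccc2c1CCCC2c1ncc[nH]1` has no single number: the several entries of compound 3 in this assay, 2150 nM; 142 nM; 234 nM (3 entries) shows its repeated entries spread widely, at 2150 nM; 142 nM; 234 nM (3 entries). Compound 4 `Cn1ccc(-c2cccc3c2CCC3c2ncc[nH]2)n1` has not yet been measured. It differs from compound 2 in one place: 1-methyl-1H-pyrazol-3-yl in place of (ethylsulfonyl)amino on an aromatic carbon. Among the measured compounds shown here, no measured pair shows a step of this kind, so the size of the effect is open. In this assay the step from compound 2 to compound 4 is expected to be a moderate loss, a 4.7-fold higher number from compound 2 to compound 4 (0.67 log units; beyond the scatter). Compound 4 is therefore estimated at 150 nM, within a range from 30 nM to 800 nM.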

Compound 4, half-maximal effective concentration: > 1300 nM
Compound 4 ended at the assay's limit; the forecaster's own chance of this, stated with the estimate: 10%; at least 8.6-fold (0.93 log units) between middle value and limit.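

Compounds 1, 2 and 3 all carry a sulfonylamino group, so they could not show whether this aromatic carbon tolerates its loss; in this assay, the exchange gives an at least 40-fold higher number from compound 2 to compound 4 (1.60 log units; beyond the scatter). Both groups hold 6 heavy atoms, so a matching count of heavy atoms does not preserve the response here. Compound 4 carries a limit of the assay, not a number: the limit of > 1300 nM in this assay, at which 1 of the 4 values shown sits.

This one step cannot separate losing the hydrogen-bond donor from adding the ring. Going by these compounds, how a plain amine or an acetylamino group would behave on this carbon remains open.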